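A few compounds are considered here, and "the series" means these few. Any claim that something is new, unique, unknown or untested is made for them only; others in the source may bear on it.

Measured in an ADME assay on microsomes from liver (Mus musculus) for metabolic stability, using NADPH, with a stated time of 10 min; a higher number here means that more of the compound is left, a lower number that less of the compound is left:
- compound 1 `NCCCCN(C[C@H]1Cc2ncccc2CN1)[C@H]1CCCc2cccnc21`: 86%
- compound 2 `NCCCCN(C[C@@H]1Cc2ncccc2CN1)[C@H]1CCCc2cccnc21`: 75%
- compound 3 `NCCCCN(C[C@H]1Cc2cccnc2CN1)[C@H]1CCCc2cccnc21`: 69%

Compound 3 lies within the scatter of compound 2 and beyond the scatter under compound 1. Next is compound 4 `NCCCCN(C[C@@H]1Cc2cccnc2CN1)[C@H]1CCCc2cccnc21`, with this change from compound 3: the two compounds have the same atoms and bonds and differ only in configuration as drawn: 1 of 2 stereo elements differ; a stereocentre at a saturated ring carbon is drawn R in compound 3 and S in compound 4. For the measured compounds named here, the one measured step that bears on it is a number 11 percentage points lower from compound 1 to compound 2 (beyond the scatter), and the only basis for that pair is the fact that compounds 1 and 2 differ only in the configuration as drawn. That step has the same drawn change at a saturated ring carbon, but compound 3 has a different core from compound 1, so it transfers only loosely. A modest fall in this assay is expected, estimated as a number 9 percentage points lower from compound 3 to compound 4 (within the scatter). For compound 4 the estimate is 60%, with an expected range of 46% to 74%.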

Compound 4, percent of the compound remaining: 25%
Compound 4: middle estimate off by 35 percentage points, on the high side; measured number below the stated range.
By their numbers in this assay, from the lowest: compound 4; then compounds 3 and 2 (each within the scatter of the next); then compound 1.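

In this assay, the drawn change from R to S at the saturated ring carbon gives a number 44 percentage points lower from compound 3 to compound 4 (beyond the scatter), a large step, whereas the core of compound 1 gave only a modest one, a number 11 percentage points lower from compound 1 to compound 2 (beyond the scatter). The direction matches in both pairs, but the size differs between the two cores. The only structural difference behind the new step is: the fact that compounds 3 and 4 differ only in the configuration as drawn

These two pairs do not show how the other stereocentre contributes. From the compounds shown here alone, it also remains open whether the fall at this carbon persists with a carboxylic acid in place of the amine.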